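Thiophene replaces bromophenyl on the ether of compound 1

A few compounds are considered here, and "the series" means these few. Any claim that something is new, unique, unknown or untested is made for them only; others in the source may bear on it.

Two members of the series have numbers in an assay on CHO cells for binding affinity to metabotropic glutamate receptor 2 (Rattus norvegicus) (on this read-out higher numbers stand for weaker inhibition and lower numbers for stronger inhibition), so far. Compound 1 `N[C@]1(C(=O)O)[C@H]2[C@@H](C[C@H]1OCc1cccc(Br)c1)[C@]2(F)C(=O)O` gives 4.71 nM in this assay. Compound 2 `N[C@]1(C(=O)O)[C@H]2[C@@H](C[C@H]1OCc1ccccc1-c1ccccc1)[C@]2(F)C(=O)O` gives 4.07 nM in this assay. The two values sit within the scatter of each other, so compound 1 cannot be separated from compound 2 on these numbers; the two aryl groups on the ether appear to be read alike.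

Compound 3 `N[C@]1(C(=O)O)[C@H]2[C@@H](C[C@H]1OCc1cccs1)[C@]2(F)C(=O)O` is the next step from compound 1. The change is thiophen-2-yl in place of 3-bromophenyl on a saturated chain carbon bound to an oxygen on a saturated carbon. Among the measured compounds shown here, no pair of measured compounds shows this kind of change, so nothing fixes its size. Given that compound 1 at 4.71 nM and compound 2 at 4.07 nM lie together, a small step is expected, most likely toward a somewhat higher number, and the expected step is a 1.7-fold higher number from compound 1 to compound 3 (0.23 log units; within the scatter). For compound 3 the estimate in this assay is 8 nM, with a range from 3 nM to 25 nM.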

Compound 3, inhibition constant: 8.79 nM
For compound 3 the middle estimate is 1.1-fold (0.04 log units) below the measured one; low and high end bracket the measured number.
By their numbers in this assay, from the lowest: compounds 2, 1 and 3 (each within the scatter of the next, the first and the last beyond it).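

Replacing 3-bromophenyl with thiophen-2-yl on the saturated chain carbon bound to an oxygen on a saturated carbon gives, in this assay, a 1.9-fold higher number from compound 1 to compound 3 (0.27 log units; within the scatter). Among the compounds shown here, this is the first step that can be read directly, and it shows that the place holds a five-membered aromatic ring with one hetero atom as well as a six-membered aromatic ring of carbon only, with no change resolved on these numbers, even though the bromine is gone. Nothing measured here bears on the reason for this result.

The compounds shown leave open whether a non-aromatic group, such as cyclohexyl or a longer alkyl chain, would be read alike in this place. They also leave open how an aryl group carrying an amine or a carboxylic acid would read.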